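A few compounds are considered here, and "the series" means these few. Any claim that something is new, unique, unknown or untested is made for them only; others in the source may bear on it.

Four compounds share one core. Compound 1 `CC(O)(CS(=O)(=O)c1ccc(F)cc1)c1cn(-c2ccc(C#N)c(C(F)(F)F)c2)nn1` and compound 2 `CC(O)(CS(=O)(=O)c1ccc(F)cc1)c1cn(-c2ccc([N+](=O)[O-])c(C(F)(F)F)c2)nn1` differ only in a group on an aromatic carbon. In a functional assay on LNCaP cells (Homo sapiens) for inhibition (on this read-out higher numbers stand for weaker inhibition and lower numbers for stronger inhibition), compound 1 gives 45000 nM, and compound 2 gives 36000 nM; the step of a 1.3-fold lower number from compound 1 to compound 2 (0.10 log units; within the scatter) lies within the scatter. Compound 3 `CCOC(=O)c1ccc(-n2cc(C(C)(O)CS(=O)(=O)c3ccc(F)cc3)nn2)cc1` instead carries an ethoxycarbonyl group. In this assay compound 3 gives > 300000 nM, which is a limit of the assay rather than a number. Going by these compounds, compound 3 thus has only a limit, sitting at the limit of > 300000 nM in this assay, at which 1 of the 3 values shown sits, so its exact position among the measured values is unknown. Compound 4 `CC(O)(CS(=O)(=O)c1ccc(F)cc1)c1cn(-c2ccc(C(=O)O)cc2)nn1` differs from compound 3 in one place: hydrogen in place of ethyl on an oxygen next to a carbonyl group. Among the compounds with values here, no measured step touches this spot; the single measured step concerns a different group and stayed within the scatter, so it offers no guide to direction or size here. With compound 3 already at a limit, compound 4 is expected to remain weak, with an estimated step of a number no higher from compound 3 to compound 4 (the limit leaves the size open). The expected value for compound 4 is 300000 nM, between 100000 nM and 1000000 nM.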

Compound 4, half-maximal inhibitory concentration: > 300000 nM
Compound 4 ended at the assay's limit; the forecaster's own chance of this, stated with the estimate: 60%; the middle value lies on the limit itself.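

Compound 3 and compound 4 both stop at a limit of the assay rather than at a number, so no step between them can be read: the limit of > 300000 nM in this assay, at which 2 of the 4 values shown sit.

The compounds shown leave open whether changing ethoxycarbonyl to carboxy alters inhibition in this assay at all.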